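Naphthalen-1-yl for phenyl on the benzylsulfanyl of compound 3

The source may hold more compounds than are shown below. What is called first, only, known or untested is meant among the compounds shown, and "the series" means these compounds.

Measured so far in a functional assay on MCF7 cells (Homo sapiens) for cytotoxicity, read by MTT assay, with a stated time of 72 h; a lower number here means a stronger inhibitor, a higher number a weaker inhibitor:
compound 1 `Cc1cc(-c2ccccc2)n(/C(N)=N/S(=O)(=O)c2cc(C)c(Cl)cc2SCc2cccc3ccccc23)n1`: 170000 nM
compound 2 `Cc1cc(S(=O)(=O)/N=C(\N)n2nccc2-c2ccccc2)c(SCc2cccc(Cl)c2)cc1Cl`: 88000 nM
compound 3 `Cc1cc(S(=O)(=O)/N=C(\N)n2nccc2-c2ccccc2)c(SCc2ccccc2)cc1Cl`: 20000 nM

Compound 3 stands lowest of the three, compound 2 above it and compound 1 furthest above. Among the compounds with values here, the only single-point step is a 4.4-fold lower number from compound 2 to compound 3 (0.64 log units; beyond the scatter), which speaks to the benzyl substituent but not to ring enlargement. Compound 4 `Cc1cc(S(=O)(=O)/N=C(\N)n2nccc2-c2ccccc2)c(SCc2cccc3ccccc23)cc1Cl` differs from compound 3 by naphthalen-1-yl in place of phenyl on a saturated chain carbon bound to a sulfur. Within the data shown here, compound 1 also carries the (naphthalen-1-yl)methyl group yet sits on a different core, so its value and that of compound 3 show only that the naphthyl-bearing compound gives the higher number. A small to modest rise is therefore expected, a 2.0-fold higher number from compound 3 to compound 4 (0.30 log units; within the scatter). Compound 4 is estimated at 40000 nM in this assay, between 12000 nM and 130000 nM.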

Compound 4, half-maximal inhibitory concentration: 58000 nM
Estimate against measurement, compound 4: 1.5-fold (0.16 log units) below; the measured number falls inside the stated range.
By their numbers in this assay, from the lowest: compound 3; then compounds 4, 2 and 1 (each within the scatter of the next, the first and the last beyond it).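

In this assay, within the data shown here, naphthalen-1-yl in place of phenyl on a saturated chain carbon bound to a sulfur gives the first reading of ring enlargement at this position (a 2.9-fold higher number from compound 3 to compound 4 (0.46 log units; beyond the scatter)), and the added aromatic ring brings no gain over compound 3. Naphthalen-1-yl and 3-chlorophenyl are not separated here (a 1.5-fold lower number from compound 2 to compound 4 (0.18 log units; within the scatter)). With naphthalen-1-yl held constant, removing the methyl group from the core of compound 1 gives a separate reading (a 2.9-fold lower number from compound 1 to compound 4 (0.47 log units; beyond the scatter)).

On these data alone, whether a methoxy group or a carboxylic acid on the phenyl, or a longer chain in place of benzyl, would hold the number of compound 3 stays open. Nothing available explains these steps.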